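A Second Fluorine on the Phenyl of Compound 3

This account rests on a few compounds, and the source may have more. Where it says the series, first, only, none or still open, it means among the compounds named here.

Of the compounds shown here, three sharing one core have been measured in a functional assay on CHO cells with adenosine receptor A1 (Homo sapiens) as the target, read by cAMP accumulation and immunoassay, with a stated time of 6 min, tested at 0.01 uM; a higher number here means a weaker effect of the compound at the concentration tested, a lower number a stronger effect. Compound 1 `Nc1scc(CN2CCN(c3cccc(Cl)c3Cl)CC2)c1C(=O)c1ccc(Cl)cc1` gives 1%, compound 2 `Nc1scc(CN2CCN(c3cccnc3)CC2)c1C(=O)c1ccc(Cl)cc1` gives 3.2%, and compound 3 `Nc1scc(CN2CCN(c3cccc(F)c3)CC2)c1C(=O)c1ccc(Cl)cc1` gives -18%. Compound 3 stands lowest of the three: the step of a number 19 percentage points lower from compound 1 to compound 3 (beyond the scatter) and the step of a number 21.2 percentage points lower from compound 2 to compound 3 (beyond the scatter) both lie beyond the scatter, while the step of a number 2.2 percentage points higher from compound 1 to compound 2 (within the scatter) does not.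

Compound 4 `Nc1scc(CN2CCN(c3cc(F)cc(F)c3)CC2)c1C(=O)c1ccc(Cl)cc1` differs from compound 3 by fluoro in place of hydrogen on an aromatic carbon, which read one bond further out is 3-fluorophenyl to 3,5-difluorophenyl. Among the compounds with values here, none of the measured steps adds a second fluoro; the two steps reaching compound 3 both replace the whole aryl group, so they set only the range in which compound 3 sits, not the effect of this addition. Compound 4 is therefore expected to show a step of about a number 3 percentage points higher from compound 3 to compound 4 (within the scatter), within the scatter. Compound 4 is estimated at -15%, with a range from -35% to 5%.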

Compound 4, a percentage reported as activity, at one concentration (the size of the read-out at that concentration, not a potency): -13%
Estimate against measurement, compound 4: 2 percentage points below, and the stated range covers the measured number.
By their numbers in this assay, from the lowest: compounds 3 and 4 (each within the scatter of the next); then compounds 1 and 2 (each within the scatter of the next).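

In this assay, within the data shown here, this is the first direct reading of a change on the phenyl itself, since the earlier steps all replaced the whole aryl group: the second fluoro, meta to a fluoro group, gives a step that cannot be told from the scatter (a number 5 percentage points higher from compound 3 to compound 4 (within the scatter)). The second fluoro also keeps the gap that compound 3 showed to the other aryl groups (a number 16.2 percentage points lower from compound 2 to compound 4 (beyond the scatter); a number 14 percentage points lower from compound 1 to compound 4 (beyond the scatter)). No measurement given here explains this result.

Going by these compounds, whether a methoxy group, a nitrile or an amine at this position would give a number like that of fluoro remains open. So does whether the gap between the fluorinated phenyl compounds and the other two holds at other concentrations, as all four readings come from a single one.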